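A few compounds are considered here, and "the series" means these few. Any claim that something is new, unique, unknown or untested is made for them only; others in the source may bear on it.

In a functional assay on HL-60 cells (Homo sapiens) for antiproliferative activity, read by MTT assay, with a stated time of 72 h (a lower number here means a stronger inhibitor, a higher number a weaker inhibitor), compound 1 (`CCOc1ccc(-c2ncnn2-c2cc(OC)c(OC)c(OC)c2)cc1`) gives 20 nM as a measured number. On these data alone, compound 2 (`COc1ccccc1-c1ncnn1-c1cc(OC)c(OC)c(OC)c1`) has no number, only the limit > 10000 nM on record, so its true value stays unknown. Compound 3 (`COc1cc(-n2ncnc2-c2ccc(SC)cc2)cc(OC)c1OC`) differs from compound 2 by 4-(methylsulfanyl)phenyl in place of 2-methoxyphenyl on an aromatic carbon. Among the compounds with values here, no measured step isolates this change, so any expectation rests on a single comparison. Compound 3 looks closer in structure to compound 1 than to compound 2, and the reading of compound 1 at 20 nM points to a strong compound. A large fall in the number is therefore expected, and the change is estimated as an at least 250-fold lower number from compound 2 to compound 3 (2.39 log units; beyond the scatter) in this assay for this pair. Compound 3 is expected at 40 nM within an estimated range of 6 nM to 400 nM once it is measured.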

Compound 3, half-maximal inhibitory concentration: 500 nM
The estimate for compound 3 lay 13-fold (1.10 log units) below the measured number; measured number outside the range, above it.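

In this assay, putting 4-(methylsulfanyl)phenyl in place of 2-methoxyphenyl on the aromatic carbon between two ring nitrogen atoms gives an at least 20-fold lower number from compound 2 to compound 3 (1.30 log units; beyond the scatter), so this position can carry a group that leaves clear activity. On these data alone, compound 2 enters that step as a limit of the assay and not as a number, so the true size of the step stays unknown: the limit of > 10000 nM in this assay, at which 1 of the 3 values shown sits. The group on the phenyl ring also counts for much, since methylsulfanyl in place of ethoxy gives a 25-fold higher number from compound 1 to compound 3 (1.40 log units; beyond the scatter), and the change from ethoxy costs a large part of the activity.

Compound 2 and compound 3 differ in both the group on the phenyl ring and the place it holds, so the compounds shown do not separate these two changes. As far as these compounds go, how a 4-methoxyphenyl or a 4-(dimethylamino)phenyl would read at this position stays open.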